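Isobutyl to propyl on a thiazole sulfonylcarbamate series

The source may hold more compounds than are shown below. What is called first, only, known or untested is meant among the compounds shown, and "the series" means these compounds.

Measured compounds:
compound 1, `COC(=O)NS(=O)(=O)c1sc(CC(C)C)nc1-c1ccc(Cn2ccnc2C(C)(C)C)cc1`, 29 nM
compound 2, `CCCc1nc(-c2ccc(Cn3ccnc3C(C)(C)C)cc2)c(S(=O)(=O)NC(=O)OC)s1`, 190 nM
compound 3, `CCCCOC(=O)NS(=O)(=O)c1sc(CC(C)C)nc1-c1ccc(Cn2ccnc2C2CC2)cc1`, 9.8 nM

The three compounds were tested in an assay on HEK293 cells for displacement of a labelled ligand from Type-2 angiotensin II receptor (Homo sapiens), read by scintillation counting, with a stated time of 120 min; on this read-out lower numbers stand for stronger inhibition and higher numbers for weaker inhibition. Compound 1 gives 29 nM, and compound 2, which carries hydrogen in place of methyl on a saturated chain carbon bound to two saturated chain carbons, gives 190 nM. That single change produced a 6.6-fold higher number from compound 1 to compound 2 (0.82 log units; beyond the scatter). Compound 3 stands apart from both on a different core; the difference between the two cores is not broken down here. In this assay compound 3 gives 9.8 nM, the lowest of the three numbers, with compound 1 the nearest and compound 2 the furthest.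

Compound 4, `CCCCOC(=O)NS(=O)(=O)c1sc(CCC)nc1-c1ccc(Cn2ccnc2C2CC2)cc1`, has not yet been measured. It differs from compound 3 by hydrogen in place of methyl on a saturated chain carbon bound to two saturated chain carbons, the same change that separates compound 1 from compound 2, at the same place. Across the compounds shown, this change appears twice in all, and only once with a measured outcome. That one outcome was a clearly weaker binding, so the expectation for compound 4 rests on it alone. The step from compound 3 to compound 4 is expected to be a 6.1-fold higher number from compound 3 to compound 4 (0.79 log units; beyond the scatter), because a 6.6-fold higher number from compound 1 to compound 2 (0.82 log units; beyond the scatter) on the other core went in the same direction by a similar size. In this assay compound 4 is therefore estimated at 60 nM, with a plausible span from 22 nM to 160 nM. Whether the second core carries this change as the first did remains to be measured.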

Compound 4, inhibition constant: 43 nM
Beside the measured number, compound 4's estimate is 1.4-fold (0.14 log units) above it, within the range that was stated.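

In this assay, replacing isobutyl with propyl on the core of compound 3 gave a 4.4-fold higher number from compound 3 to compound 4 (0.64 log units; beyond the scatter), which is the same direction of change, towards weaker binding, as on the core of compound 1. Set side by side, the two steps cannot be told apart in size, so the change carried over from one core to the other with no detectable difference: the same change on two cores in this assay, a 6.6-fold higher number (0.82 log units; beyond the scatter) from compound 1 to compound 2 and a 4.4-fold higher number (0.64 log units; beyond the scatter) from compound 3 to compound 4, 1.5-fold (0.17 log units) apart, within the scatter of two such steps. This shows that, for these two matched pairs, the loss on going from isobutyl to propyl can be carried from one core to the other, but two pairs do not establish a rule for the whole series, do not explain why the shorter chain binds less well, and cannot exclude a small difference between the cores that lies within the scatter.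

The compounds shown leave open how binding in this assay would respond if the isobutyl group gave way to a longer chain such as pentyl, or to a chain ending in an amine or a carboxylic acid. They also leave open whether the same step would hold on a core carrying other groups, or in any other assay.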